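Swapping the sulfonyl aryl group among compounds at the assay limit

This account rests on a few compounds, and the source may have more. Where it says the series, first, only, none or still open, it means among the compounds named here.

Compound 2 (`CC1CCN(C2CCN(S(=O)(=O)c3cnc(Cl)s3)CC2)CC1`) gives > 10000 nM in an ADME assay on HCT-116 cells (Homo sapiens) for cytotoxicity, read by CellTiter-Glo, with a stated time of 72 h (a higher number here means a weaker inhibitor, a lower number a stronger inhibitor), and that value is a limit. Compound 2 therefore stands at the limit of > 10000 nM in this assay, at which 1 of the 3 values shown sits, and has no exact number. Compound 1 (`CCCC(=O)N(Cc1ccccc1)C1CCN(S(=O)(=O)c2c(C)cc(C)cc2C)CC1`) gives > 5000 nM in this assay and this is also a limit. Compound 3 (`Cc1cc(C)c(S(=O)(=O)N2CCC(N3CCN(C)CC3)CC2)c(C)c1`) gives > 5000 nM in this assay and this too is a limit. Within the data shown here, none of the three measured compounds has an exact value, and no step between them can be read from the data.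

The next compound, compound 4 (`CC1CCN(C2CCN(S(=O)(=O)c3ccc(Br)c(Cl)c3)CC2)CC1`), has not yet been measured. Compared with compound 2, it carries 4-bromo-3-chlorophenyl in place of 2-chloro-1,3-thiazol-5-yl on a sulfonyl sulfur, and the counted difference is 4-bromo-3-chlorophenyl in place of 2-chloro-1,3-thiazol-5-yl on a sulfonyl sulfur in full.

The expected change, an at least 1.2-fold lower number from compound 2 to compound 4 (0.09 log units; that floor lies within the scatter), is none beyond the scatter, so no direction is predicted. Among the measured compounds shown here, this expectation rests on compound 2 at > 10000 nM as a limit, and it remains uncertain because no measured step is available to size it. In this assay compound 4 is expected at 8000 nM with an estimated range from 3000 nM to 20000 nM as its span, and the assay may again report only a limit.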

Compound 4, half-maximal inhibitory concentration: > 5000 nM
Compound 4 gave a limit, no number; the forecaster's own chance of this, stated with the estimate: 65%; the middle value is on the limit's open side.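

No new step can be read: compound 2 and compound 4 both give only limits in this assay, so the effect of 4-bromo-3-chlorophenyl in place of 2-chloro-1,3-thiazol-5-yl on a sulfonyl sulfur stays unreadable. The compounds shown leave open what exact value any of them has in this assay, and whether changing the group on the sulfonyl sulfur shifts that value at all.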